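A few compounds are considered here, and "the series" means these few. Any claim that something is new, unique, unknown or untested is made for them only; others in the source may bear on it.

Compound 3, `COc1cc2c(Oc3ccc(NC(=O)c4cn(-c5ccccc5)nn4)cc3F)ccnc2cc1OCCCN1CCCCC1`, is examined in a functional assay on NCI-H460 cells (Homo sapiens) for cytotoxicity, read by MTT assay, with a stated time of 72 h (on this read-out lower numbers stand for stronger inhibition and higher numbers for weaker inhibition), where it gives 210 nM. Among the three measured compounds it holds the second highest number. Within the data shown here, compound 1, `COc1cc2c(Oc3ccc(NC(=O)c4cn(-c5ccccc5Cl)nn4)cc3F)ccnc2cc1OCCCN1CCCC1`, gives 190 nM in this assay, and the two values lie within the scatter of each other; compound 1 and compound 3 differ in more than one place, so no single step joins them. Compound 2, `COc1cc2c(Oc3ccc(NC(=O)c4cn(-c5c(C)cccc5C)nn4)cc3F)ccnc2cc1OCCCN1CCCC1`, gives 1560 nM, which stands well apart from compound 3.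

Compound 4, `COc1cc2c(Oc3ccc(NC(=O)c4cn(-c5c(Cl)cccc5Cl)nn4)cc3F)ccnc2cc1OCCCN1CCCCC1`, carries 2,6-dichlorophenyl in place of phenyl on an aromatic nitrogen. Among the measured compounds shown here, the one measured step that bears on such a change is an 8.2-fold higher number from compound 1 to compound 2 (0.91 log units; beyond the scatter), in which a second group on the phenyl, flanking the aromatic nitrogen on both sides, went with a clearly higher number. For the measured compounds named here, the new compound places two chlorine atoms in the same pattern of substitution, though the change starts from an unsubstituted phenyl rather than from a singly substituted one, and no measured pair shows a dichlorophenyl directly.

On that basis a step of similar size and direction is expected, and compound 4 is estimated at 1100 nM, with a likely range from 350 nM to 3500 nM. The expected step is a 5.2-fold higher number from compound 3 to compound 4 (0.72 log units; beyond the scatter).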

Compound 4, half-maximal inhibitory concentration: 280 nM
Beside the measured number, compound 4's estimate is 3.9-fold (0.59 log units) above it, and the stated range ends above it.
By their numbers in this assay, from the lowest: compounds 1, 3 and 4 (each within the scatter of the next); then compound 2.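

In this assay, the change from phenyl to 2,6-dichlorophenyl on the aromatic nitrogen is a 1.3-fold higher number from compound 3 to compound 4 (0.12 log units; within the scatter), so this larger group enters at that position without a step beyond the scatter. Among these compounds, the earlier step at the same position, an 8.2-fold higher number from compound 1 to compound 2 (0.91 log units; beyond the scatter), had suggested that a phenyl carrying two groups there goes with a clearly higher number, but the new step shows that this does not hold for every such phenyl, and only the step to compound 2 follows that pattern. No measurement is available here that explains why one step lies beyond the scatter and the other within it.

The two steps start from different groups and belong to compounds that also differ elsewhere, so the compounds shown do not separate the effect of the entering group from that of its surroundings, and the 2,6-dimethylphenyl and 2,6-dichlorophenyl groups are never compared on the same compound. On these data alone, it also remains open how this position would respond to a benzyl group, or to a phenyl carrying an amine or a carboxylic acid.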